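Nitro for methoxy on the pendant phenyl ring

This account rests on a few compounds, and the source may have more. Where it says the series, first, only, none or still open, it means among the compounds named here.

Three compounds have numbers in a functional assay on SNU-475 cells (Homo sapiens) for inhibition, read by sulforhodamine B assay, with a stated time of 72 h; a lower number here means a stronger inhibitor, a higher number a weaker inhibitor. Compound 1 `CC(C)Cc1ccc(C(C)c2n[nH]c(=S)n2N)cc1` gives 11700 nM. Compound 3 `COc1ccc2cc(C(C)c3n[nH]c(=S)n3N)ccc2c1` gives 15900 nM. Compound 2 `COc1ccc(C2=Nn3c(nnc3C(C)c3ccc(-c4ccccc4)c(F)c3)SC2)cc1` gives 6700 nM, the lowest of the three; its number and that of compound 1 lie within the scatter of each other, while the gap to compound 3 lies beyond it. Among the measured compounds shown here, no pair among the measured compounds differs in one place only, so no single step is on record.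

Compound 4 `CC(c1ccc(-c2ccccc2)c(F)c1)c1nnc2n1N=C(c1ccc([N+](=O)[O-])cc1)CS2` has not yet been measured in this assay. It differs from compound 2 by nitro in place of methoxy on an aromatic carbon, a nitro in place of methoxy on an aromatic carbon. For the measured compounds named here, nothing among the measured compounds shows how this exchange plays out, so no direction can be read from them. The expected step in this assay is a 1.1-fold lower number from compound 2 to compound 4 (0.05 log units; within the scatter), none beyond the scatter. Compound 4 is estimated at 6000 nM, with a range from 2500 nM to 15000 nM.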

Compound 4, half-maximal inhibitory concentration: 7100 nM
The estimate for compound 4 lay 1.2-fold (0.07 log units) below the measured number; low and high end bracket the measured number.
By their numbers in this assay, from the lowest: compounds 2, 4, 1 and 3 (each within the scatter of the next, the first and the last beyond it).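

Among the compounds shown here, exchanging 4-methoxyphenyl for 4-nitrophenyl gives the first single-place step on record in this assay (a 1.1-fold higher number from compound 2 to compound 4 (0.03 log units; within the scatter)), and it lies within the scatter. On this aromatic carbon, para to a large group, the assay therefore reads methoxy and nitro alike, although the two groups differ in heavy atoms and in hydrogen-bond acceptors. No measurement on record offers an explanation for this result.

Going by these compounds, whether this position remains as insensitive with an amine, a carboxylic acid or a longer chain such as butoxy in the same place remains open. For the compounds shown here, compound 1 and compound 3 each differ from compound 2 and compound 4 in more than one place, so no steps to them can be read and the contribution of the core stays unresolved.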